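Swapping Hydroxy for Trifluoromethyl on the Amide-Side Ring

The source may hold more compounds than are shown below. What is called first, only, known or untested is meant among the compounds shown, and "the series" means these compounds.

Compound 2 `CN(C)C(=O)c1cc2cnc(Nc3ccc(NC(=O)C4(C(=O)Nc5ccc(O)cc5)CC4)cc3)nc2n1C1CCCC1` gives 94.4% in a functional assay on A549 cells (Homo sapiens) for inhibition, read by CCK-8 assay, with a stated time of 72 h, tested at 10 uM (on this read-out higher numbers stand for more inhibition of growth at the one concentration tested and lower numbers for less inhibition of growth), the highest of the two numbers shown, with compound 1 `CN(C)C(=O)c1cc2cnc(Nc3ccc(NC(=O)C4(C(=O)Nc5cccc(C(F)(F)F)c5)CC4)cc3)nc2n1C1CCCC1` nearest at 89.2%, a gap within the scatter. Compound 3 `CN(C)C(=O)c1cc2cnc(Nc3ccc(NC(=O)C4(C(=O)Nc5ccc(C(F)(F)F)cc5)CC4)cc3)nc2n1C1CCCC1` is not yet measured; it differs from compound 2 by trifluoromethyl in place of hydroxy on an aromatic carbon. Within the data shown here, the only related step, a number 5.2 percentage points higher from compound 1 to compound 2 (within the scatter), left the trifluoromethyl and hydroxy variants at nearly the same level. A step within the scatter is therefore expected, a number 4.4 percentage points lower from compound 2 to compound 3 (within the scatter). Compound 3 is estimated at 90%, between 80% and 97%.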

Compound 3, percent growth inhibition at one concentration: 87.9%
Beside the measured number, compound 3's estimate is 2.1 percentage points above it; the measured number falls inside the stated range.
By their numbers in this assay, from the lowest: compounds 3, 1 and 2 (each within the scatter of the next).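

In this assay, trifluoromethyl in place of hydroxy on the aromatic carbon gives a number 6.5 percentage points lower from compound 2 to compound 3 (within the scatter), so this direct swap at one ring position does not separate the two groups. Using 4-(trifluoromethyl)phenyl in place of 3-(trifluoromethyl)phenyl gives a number 1.3 percentage points lower from compound 1 to compound 3 (within the scatter), so these two placements of trifluoromethyl cannot be told apart either. Nothing available explains this shared level of growth inhibition. On these data alone, whether an amine or a carboxylic acid in this place would read differently remains open. A single tested concentration also leaves open whether these compounds would differ at other concentrations.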